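Swapping the Aryl Group: Expecting a Fluorophenyl Analogue's Inhibition

The compounds below may be only part of what the source reports. "The series", "measured", "known", "first", "only" and "open" are said of these compounds alone.

Measured so far:
Compound 1, `CS(=O)(=O)c1ccc(N2N=C(c3ccc(Br)cc3)CCC2=O)cc1`: 31.5%
Compound 2, `CS(=O)(=O)c1ccc(N2N=C(c3ccc(O)c(Cl)c3)CCC2=O)cc1`: 55.2%

In a functional assay on the whole organism (strain Wistar) for inhibition, with Rattus norvegicus as the target, read by paw edema, with stated times of 30 min and 5 h, at a dose of 0.05 mmol/kg by the oral route (on this read-out higher numbers stand for more inhibition at the one dose given (going by the name of the read-out) and lower numbers for less inhibition), compound 1 gives 31.5%, while compound 2 gives 55.2%. Among the measured compounds shown here, compound 2 thus stands highest of the two numbers, and the single measured step, a number 23.7 percentage points higher from compound 1 to compound 2 (beyond the scatter), lies beyond the scatter.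

Compound 3, `CS(=O)(=O)c1ccc(N2N=C(c3ccc(F)cc3)CCC2=O)cc1`, is the next candidate. It differs from compound 2 in one place: 4-fluorophenyl in place of 3-chloro-4-hydroxyphenyl on a carbon with a double bond to nitrogen. For the measured compounds named here, only one measured step bears on this change, the step from compound 1 to compound 2, and compound 3 in effect runs that step backwards, since a 4-fluorophenyl, like the 4-bromophenyl of compound 1, carries no hydroxyl and no chlorine. With one halogen exchanged for another, the nearest guide is compound 1, whose value of 31.5% is the anchor for the expectation. A downward step beyond the scatter is therefore expected, of roughly the size seen in a number 23.7 percentage points higher from compound 1 to compound 2 (beyond the scatter) but in the opposite direction. Compound 3 is expected to give about 33%, within a range of 18% to 48%. The expectation for compound 3 thus amounts to a step of a number 22.2 percentage points lower from compound 2 to compound 3 (beyond the scatter).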

Compound 3, a percentage reported as inhibition, in the whole organism at one dose (the size of the read-out at that dose, not a potency): 73.6%
The estimate for compound 3 lay 40.6 percentage points below the measured number; measured number outside the range, above it.
By their numbers in this assay, from the lowest: compound 1; then compound 2; then compound 3.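

On the carbon with a double bond to nitrogen, the two single-halogen phenyl groups are not interchangeable: in this assay the fluoro in place of bromo on an aromatic carbon gives a number 42.1 percentage points higher from compound 1 to compound 3 (beyond the scatter) and is the largest step among these compounds. A hydroxyl and a chlorine are also not needed for a high number here, since 4-fluorophenyl in place of 3-chloro-4-hydroxyphenyl gives a number 18.4 percentage points higher from compound 2 to compound 3 (beyond the scatter) even though the entering group has 0 hydrogen-bond donors and the leaving group has 1. Nothing available explains why these steps have this direction or size.

Because 3-chloro-4-hydroxyphenyl differs from 4-fluorophenyl in two groups at once, the compounds shown cannot separate what the chlorine and the hydroxyl each contribute, and a 4-chlorophenyl or a 4-hydroxyphenyl analogue would be needed to show that. Also open, on these data alone, is what an unsubstituted phenyl, a 4-methoxyphenyl or a 4-aminophenyl would give on the same carbon, and so whether fluorine stands out or bromine simply falls short.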